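Two Amide Caps on a Shared Core, a Third Awaited

This account rests on a few compounds, and the source may have more. Where it says the series, first, only, none or still open, it means among the compounds named here.

Compound 1 `O=C(COc1ccc2cc(/C=C3/SC(=O)NC3=O)ccc2c1)Nc1ccccc1`: 4500 nM
Compound 2 `Cc1cccc(NC(=O)COc2ccc3cc(/C=C4/SC(=O)NC4=O)ccc3c2)n1`: 7500 nM

Of the compounds shown here, two have been measured in an assay on isolated protein for inhibition of histone deacetylase 8 (Homo sapiens), with a stated time of 1 h; a higher number here means a weaker inhibitor, a lower number a stronger inhibitor. Among the compounds with values here, compound 1 gives 4500 nM and compound 2 gives 7500 nM; the only step between them, a 1.7-fold higher number from compound 1 to compound 2 (0.22 log units; within the scatter), is a change of 6-methylpyridin-2-yl for phenyl on an amide-type nitrogen, and it stays within the scatter, so compound 2 cannot be set apart from compound 1 on these numbers.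

Compound 3 `Cc1cc(NC(=O)COc2ccc3cc(/C=C4/SC(=O)NC4=O)ccc3c2)no1` is not yet measured. It differs from compound 2 in one place: 5-methyl-1,2-oxazol-3-yl in place of 6-methylpyridin-2-yl on an amide-type nitrogen. Within the data shown here, the sole measured step that bears on this position, the one from compound 1 to compound 2, exchanged one aromatic cap for another and moved the read-out by no more than the scatter. On that evidence a second exchange of the cap at the same amide-type nitrogen is expected to leave the read-out where it is, with no step beyond the scatter in either direction. Compound 3 is therefore estimated at 7000 nM, within a range of 3000 nM to 18000 nM, which means an expected step of a 1.1-fold lower number from compound 2 to compound 3 (0.03 log units; within the scatter).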

Compound 3, half-maximal inhibitory concentration: > 50000 nM
Compound 3 was reported as a limit (the forecaster's own chance of this, stated with the estimate: 10%); middle value at least 7.1-fold (0.85 log units) from the limit.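

The cap on the amide-type nitrogen turns out to matter more than the first pair suggested: placing 5-methyl-1,2-oxazol-3-yl there gives an at least 6.6-fold higher number from compound 2 to compound 3 (0.82 log units; beyond the scatter), and against the phenyl cap it gives an at least 11-fold higher number from compound 1 to compound 3 (1.04 log units; beyond the scatter). Within the data shown here, the two six-membered aromatic caps could not be told apart, so the five-membered ring with 2 hetero atoms is the first cap at this position to give a step beyond the scatter, and the position is evidently not open to any aromatic ring. In this assay compound 3 is reported only as a limit, > 50000 nM, so both steps are lower bounds and their true size stays unknown: the limit of > 50000 nM in this assay, at which 1 of the 3 values shown sits.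

The compounds shown do not separate the parts of this exchange, since ring size and the hetero atoms change together, and no cause for the step can be read from them. A 1,3-thiazol-2-yl cap, or an unsubstituted 1,2-oxazol-3-yl or pyridin-2-yl cap, would be needed to tell whether the five-membered ring, its ring oxygen or the position of the methyl group goes with the step.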